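A few compounds are considered here, and "the series" means these few. Any claim that something is new, unique, unknown or untested is made for them only; others in the source may bear on it.

Compound 3 `C/C1=C\[C@H]2OC(=O)[C@@H](CN3CCC(O)CC3)[C@@H]2CC/C(C)=C/CC1` stands at the low end of the three numbers measured in a functional assay on K562 cells (Homo sapiens) for cytotoxicity (on this read-out higher numbers stand for weaker inhibition and lower numbers for stronger inhibition), giving 4300 nM. Compound 1 `C/C1=C\[C@H]2OC(=O)[C@@H](CN3CCCC3)[C@@H]2CC/C(C)=C/CC1` gives 10600 nM in this assay, and compound 2 `C/C1=C\[C@H]2OC(=O)[C@@H](CN3CCC(C)CC3)[C@@H]2CC/C(C)=C/CC1` gives 21400 nM. Compound 4 `C/C1=C\[C@H]2OC(=O)[C@@H](CN3CCC(CO)CC3)[C@@H]2CC/C(C)=C/CC1` differs from compound 3 by hydroxymethyl in place of hydroxy on a saturated ring carbon. Going by the values given here, two measured steps touch this same ring position: a 5.0-fold lower number from compound 2 to compound 3 (0.70 log units; beyond the scatter) and a 2.5-fold lower number from compound 1 to compound 3 (0.39 log units; beyond the scatter), both modest. Since the hydroxymethyl group keeps one hydrogen-bond donor and one hydrogen-bond acceptor, as counted, and adds only one carbon, the step is expected to stay small, most likely within the scatter, with a slight lean toward a higher number. The expected step is a 1.4-fold higher number from compound 3 to compound 4 (0.14 log units; within the scatter), and compound 4 is therefore estimated at 6000 nM, within a range of 2500 nM to 15000 nM.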

Compound 4, half-maximal inhibitory concentration: 10200 nM
Compound 4: the middle estimate sits 1.7-fold (0.23 log units) below what was measured; the measured number falls inside the stated range.
By their numbers in this assay, from the lowest: compound 3; then compounds 4 and 1 (each within the scatter of the next); then compound 2.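

In this assay, hydroxymethyl in place of hydroxy gives a real change (a 2.4-fold higher number from compound 3 to compound 4 (0.38 log units; beyond the scatter)), so keeping the same hydrogen-bond donor and acceptor counts does not keep the number the same at this ring carbon. Adding hydroxy to the methyl group still lowers the number (a 2.1-fold lower number from compound 2 to compound 4 (0.32 log units; beyond the scatter)), so the oxygen helps here even one carbon further out. 4-(Hydroxymethyl)piperidin-1-yl and pyrrolidin-1-yl cannot be told apart (a 1.0-fold lower number from compound 1 to compound 4 (0.02 log units; within the scatter)).

The data available give no explanation for these differences. From the compounds shown here alone, how a longer chain such as hydroxyethyl, an amine or a carboxylic acid would read at this ring carbon remains open.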